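Swapping the Aryl Ring on the Sulfonyl Group

The source may hold more compounds than are shown below. What is called first, only, known or untested is meant among the compounds shown, and "the series" means these compounds.

Among the measured compounds shown here, compound 2 `NC[C@@H]1CCCc2cc(S(=O)(=O)c3cccc(F)c3)ccc21` gives 0.0794 nM in an assay on isolated protein for displacement of a labelled ligand from 5-hydroxytryptamine receptor 6 (Homo sapiens) (on this read-out higher numbers stand for weaker inhibition and lower numbers for stronger inhibition), the lower of the two numbers measured so far, with compound 1 `COc1cccc(S(=O)(=O)c2ccc3c(c2)CCC[C@H]3CN)c1` at 0.398 nM. For the measured compounds named here, the only known step, a 5.0-fold lower number from compound 1 to compound 2 (0.70 log units; beyond the scatter), concerns a single substituent on that aromatic ring. Compound 3 `Cn1ccc(S(=O)(=O)c2ccc3c(c2)CCC[C@H]3CN)c1` replaces the whole ring instead: 1-methyl-1H-pyrrol-3-yl in place of 3-fluorophenyl on a sulfonyl sulfur. Going by the values given here, no measured step covers such a ring swap, so the expectation rests on the size of the known step alone; a move to a higher number, a 6.3-fold higher number from compound 2 to compound 3 (0.80 log units; beyond the scatter), is expected. Compound 3 is estimated at 0.5 nM, between 0.1 nM and 3 nM.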

Compound 3, inhibition constant: 7.94 nM
For compound 3 the middle estimate is 16-fold (1.20 log units) below the measured one; measured number above the stated range.
By their numbers in this assay, from the lowest: compound 2; then compound 1; then compound 3.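

Replacing the whole ring on the sulfonyl sulfur moves the number in this assay much further than changing one substituent on that ring: a 100-fold higher number from compound 2 to compound 3 (2.00 log units; beyond the scatter), against a 5.0-fold lower number from compound 1 to compound 2 (0.70 log units; beyond the scatter). This position therefore responds strongly to the identity of the ring, and 1-methyl-1H-pyrrol-3-yl is a poor replacement for 3-fluorophenyl on this read-out. No measured evidence accounts for the size of this step.

On these data alone, it remains open whether the five-membered ring or its methyl group matters more. Also open, as far as these compounds go, is how a pyridine or thiophene ring would fare in this place.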